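Anilide to thiazolyl amide: expected weaker cell inhibition

This account rests on a few compounds, and the source may have more. Where it says the series, first, only, none or still open, it means among the compounds named here.

Measured compounds:
compound 1 `CCc1ccc(NC(=O)C2CCN(C/C=C/c3ccccc3)CC2)cc1` — 11600 nM
compound 2 `CC(C)c1ccc(NC(=O)C2CCN(C/C=C/c3ccccc3)CC2)cc1` — 5200 nM
compound 3 `O=C(Nc1cccc2cccnc12)C1CCN(C/C=C/c2ccccc2)CC1` — 38200 nM

In a functional assay on MGC-803 cells (Homo sapiens) for inhibition, read by MTT assay, with a stated time of 72 h (on this read-out higher numbers stand for weaker inhibition and lower numbers for stronger inhibition), compound 2 has the lowest number of the three. Within the data shown here, the one single-point step, a 2.2-fold lower number from compound 1 to compound 2 (0.35 log units; beyond the scatter), is modest but beyond the scatter. Compound 3 gives the highest number in this assay.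

Compound 4 `O=C(Nc1nccs1)C1CCN(C/C=C/c2ccccc2)CC1` differs from compound 2 by 1,3-thiazol-2-yl in place of 4-isopropylphenyl on an amide-type nitrogen. Among the measured compounds shown here, the step of a 2.2-fold lower number from compound 1 to compound 2 (0.35 log units; beyond the scatter) alters only the alkyl group on the phenyl and says little about exchanging the ring itself; no measured step swaps the aromatic amide substituent. The values of compound 2 and compound 3 show that the one such exchange among these compounds goes with a higher number. Compound 4 is therefore expected to show a 3.8-fold higher number from compound 2 to compound 4 (0.59 log units; beyond the scatter) in this assay. Compound 4 is estimated at 20000 nM, in the range 6000 nM to 65000 nM.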

Compound 4, half-maximal inhibitory concentration: 16400 nM
Estimate against measurement, compound 4: 1.2-fold (0.09 log units) above, and the stated range covers the measured number.
By their numbers in this assay, from the lowest: compound 2; then compounds 1 and 4 (each within the scatter of the next); then compound 3.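

Among these compounds, on the amide-type nitrogen, 1,3-thiazol-2-yl in place of 4-isopropylphenyl gives a 3.2-fold higher number from compound 2 to compound 4 (0.50 log units; beyond the scatter) in this assay and is the first direct read on exchanging this ring. 1,3-thiazol-2-yl in place of 4-ethylphenyl gives a 1.4-fold higher number from compound 1 to compound 4 (0.15 log units; within the scatter) in the same assay, so the size of the exchange depends on the alkyl group on the phenyl that leaves. Nothing measured here accounts for either step.

Open, as far as these compounds go, is whether an oxazol-2-yl or pyridin-2-yl group on this nitrogen would read like 1,3-thiazol-2-yl. Also open, from the compounds shown here alone, is what a methyl group on the 1,3-thiazol-2-yl would do.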